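The compounds below may be only part of what the source reports. "The series", "measured", "known", "first", "only" and "open" are said of these compounds alone.

Measured compounds, with their readings in a functional assay on Sf9 cells for antagonist activity at histamine H2 receptor (Homo sapiens), with stated times of 2 min and 20 min; a higher number here means a more potent compound, by a factor of ten per unit of this negative logarithm, a lower number a less potent compound:
- compound 1, `CC(CC(=O)/N=C(\N)NCCCc1ccccc1)c1ccccc1`: 5.89
- compound 2, `N/C(=N\C(=O)CC(c1ccccc1)c1ccccc1)NCCCc1ccccc1`: 5.89

For the measured compounds named here, compound 1 stands level with compound 2 at the digits recorded; the one measured step, no change at the digits printed from compound 1 to compound 2 (within the scatter), lies within the scatter, so the two values give no order between them.

Compound 3 is `CC(CC(=O)/N=C(\N)NCCCc1ccncc1)c1ccccc1`. Relative to compound 1 the change is pyridin-4-yl in place of phenyl on a saturated chain carbon, three bonds along the chain from an amine nitrogen. Going by the values given here, only one measured step exists, and it alters the same saturated chain carbon, but by putting a phenyl in place of a methyl rather than exchanging one aromatic ring for another; no measured pair exchanges phenyl for pyridin-4-yl anywhere in the molecule. Among the compounds with values here, the single step, no change at the digits printed from compound 1 to compound 2 (within the scatter), shows that this position tolerated a substantial addition without a shift beyond the scatter, which is the only guide available. On these data alone, a step in this assay of no size beyond the scatter is therefore expected, with the uncertainty widened because the ring exchange itself is untested. The estimated step of a number 0.19 log units lower from compound 1 to compound 3 (within the scatter) reflects this. Compound 3 is estimated at 5.7, with a range from 5.1 to 6.3.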

Compound 3, negative logarithm of the antagonist equilibrium constant: 5.54
For compound 3 the middle estimate is 0.16 log units above the measured one; the measured number falls inside the stated range.
By their numbers in this assay, from the lowest: compound 3; then compounds 1 and 2 (each within the scatter of the next).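

For the compounds shown here, the exchange of phenyl for pyridin-4-yl on the saturated chain carbon, three bonds along the chain from an amine nitrogen, is the first change to give a step beyond the scatter in this assay (a number 0.35 log units lower from compound 1 to compound 3 (beyond the scatter)). The only earlier step (no change at the digits printed from compound 1 to compound 2 (within the scatter)) lay at a different place in the molecule and within the scatter, so the reading is now shown not to be indifferent to every single change, although this step is modest. The exchange keeps the count of six heavy atoms and adds one ring nitrogen and one hydrogen-bond acceptor, but no measurement on these compounds says what lies behind the step.

With one ring exchange at this place, the compounds shown do not say whether the step depends on where the ring nitrogen sits, which pyridin-3-yl or pyridin-2-yl at the same carbon would test. They also leave open whether another replacement there, such as a ring bearing a methoxy group or an amino group, would give a step of the same direction or size.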